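Replacing methoxycarbonyl with methyl: expected half-life

A few compounds are considered here, and "the series" means these few. Any claim that something is new, unique, unknown or untested is made for them only; others in the source may bear on it.

Compound 1, `CCCC(CCC)C(=O)N(C)/N=N/c1ccc(C(=O)OCC)cc1`: 34.1 h
Compound 2, `CCCC(CCC)C(=O)N(C)/N=N/c1ccc(C(C)=O)cc1`: a limit, > 40 h
Compound 3, `CCCC(CCC)C(=O)N(C)/N=N/c1ccc(C(=O)OC)cc1`: 31.4 h

These three compounds share one core and differ only in the group on the aromatic ring. In a physicochemical assay for pharmacokinetics, read by HPLC, in phosphate buffer, at pH 7.4 (on this read-out higher numbers stand for a longer-lived compound and lower numbers for a shorter-lived compound), compound 1 gives 34.1 h and compound 3 gives 31.4 h. For compound 2 the result in this assay is a limit, > 40 h. Compound 3 holds the lowest of the two plain numbers, but its nearest neighbour is compound 1 and the step of a 1.1-fold lower number from compound 1 to compound 3 (0.04 log units; within the scatter) stays within the scatter. The step of an at least 1.2-fold lower number from compound 2 to compound 3 (0.10 log units; that floor lies within the scatter) has its floor set by the limit of > 40 h in this assay, at which 1 of the 3 values shown sits, and also stays within the scatter.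

Compound 4, `CCCC(CCC)C(=O)N(C)/N=N/c1ccc(C)cc1`, has not yet been measured. It differs from compound 3 by methyl in place of methoxycarbonyl on an aromatic carbon. Within the data shown here, no measured step removes the whole methoxycarbonyl group; the two steps at hand only exchange what sits on a carbonyl carbon or on the chain bound to its oxygen, and neither leaves the scatter. In this assay, therefore, no step beyond the scatter is expected for compound 4, and the estimated step is a 1.1-fold higher number from compound 3 to compound 4 (0.05 log units; within the scatter). Compound 4 is expected to give about 35 h, between 20 h and 60 h.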

Compound 4, half-life: 31.3 h
Compound 4: middle estimate off by 1.1-fold (0.05 log units), on the high side; measured number inside the range.
By their numbers in this assay, from the lowest: compounds 4, 3 and 1 (each within the scatter of the next). At a limit, above all of these: compound 2.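

Earlier steps only exchanged what sits on a carbonyl carbon or on the chain bound to its oxygen, whereas here the whole group on the aromatic carbon gives way to methyl. In this assay this larger change still stays within the scatter, with a 1.0-fold lower number from compound 3 to compound 4 (0.00 log units; within the scatter) and with a 1.1-fold lower number from compound 1 to compound 4 (0.04 log units; within the scatter) as the two steps that can be read in full, while an at least 1.2-fold lower number from compound 2 to compound 4 (0.10 log units; that floor lies within the scatter) gives only a floor. Compound 2 stands at a limit and not at a number: the limit of > 40 h in this assay, at which 1 of the 4 values shown sits.

How an amine, a carboxylic acid or a longer chain on this aromatic carbon would behave stays open, since the groups shown here carry no net charge. Also open, on these data alone, is whether the same holds on any core other than the shared one.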